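Phenylsulfonyl in place of benzoyl on the chain carbon

The source may report more compounds than this note shows. Statements on the series, on what has been measured and on what is new or still open speak of the compounds shown alone.

Among the compounds with values here, the series so far is read only in a functional assay on SK-MEL-2 cells (Homo sapiens) for inhibition, read by sulforhodamine B assay, with a stated time of 48 h; a higher number here means a weaker inhibitor of growth, a lower number a stronger inhibitor of growth. Compound 1 `N#C/C(=C\c1c(-c2ccccc2)[nH]c2ccccc12)C(=O)c1ccccc1` gives 35200 nM in this assay and stands highest of the three numbers measured. The nearest neighbour, compound 2 `COc1ccc2[nH]c(-c3ccccc3)c(C=C(C#N)C#N)c2c1`, gives 5900 nM in this assay, a gap beyond the scatter, and compound 3 `COc1ccc(-c2[nH]c3ccc(OC)cc3c2C=C(C#N)C#N)cc1` gives 5900 nM in this assay, equally far from compound 1. Within the data shown here, the one single-point step measured, no change at the digits printed from compound 2 to compound 3 (within the scatter), concerns a methoxy group on an aromatic carbon and not the substituent on the chain, so it does not bear on the change now at hand.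

Compound 4 `N#C/C(=C\c1c(-c2ccccc2)[nH]c2ccccc12)S(=O)(=O)c1ccccc1` differs from compound 1 by phenylsulfonyl in place of benzoyl on a double-bonded chain carbon bound to a double-bonded chain carbon and a triple-bonded carbon. Among the measured compounds shown here, no measured pair exchanges the benzoyl on that chain carbon for anything else, so the size of this step has no precedent in the data. In the absence of such a precedent the expectation is a step no larger than the scatter in either direction, held with a wide range. Compound 4 is estimated at 30000 nM in this assay, expected to fall between 8000 nM and 100000 nM. The expected step of a 1.2-fold lower number from compound 1 to compound 4 (0.07 log units; within the scatter) is accordingly estimated as essentially none.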

Compound 4, concentration for 50% growth inhibition: 12700 nM
Estimate against measurement, compound 4: 2.4-fold (0.37 log units) above; the range from low to high includes it.
By their numbers in this assay, from the lowest: compounds 2 and 3 (each within the scatter of the next); then compound 4; then compound 1.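

In this assay, within the data shown here, the chain carbon named in this exchange responds to its substituent: phenylsulfonyl in place of benzoyl gives a 2.8-fold lower number from compound 1 to compound 4 (0.44 log units; beyond the scatter) and is the first step read at this place, as the only earlier step concerned a methoxy group on an aromatic carbon. The step is modest in size, and both groups carry one six-membered aromatic ring of carbon only, so the exchange at this place retains measurable growth inhibition with that ring kept and the carbonyl link replaced by a sulfonyl link. Nothing available here assigns the step to any particular feature of the exchange, and its cause stays unassigned.

The compounds shown do not separate the contribution of the sulfonyl link from that of the phenyl ring on it, a question that a methylsulfonyl group or a carboxylic acid on the same chain carbon would address. Also open, from the compounds shown here alone, is whether phenylsulfonyl in place of benzoyl gives a step of similar size when methoxy stands on the shared core, as it does in compound 2.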